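Swapping a thiophene ring for an ethoxy group on a thiophene

The source may report more compounds than this note shows. Statements on the series, on what has been measured and on what is new or still open speak of the compounds shown alone.

Measured compounds:
compound 1, `C[C@H]1[C@H](NCc2sccc2C2CC2)C[C@H]2C[C@@H]1C2(C)C`, 25000 nM
compound 2, `C[C@H]1[C@H](NCc2sccc2-c2ccsc2)C[C@H]2C[C@@H]1C2(C)C`, 12500 nM

Both were tested in an ADME assay on MDCK cells (Canis lupus familiaris) for cytotoxicity, read by microscopy, with a stated time of 48 h; on this read-out lower numbers stand for higher toxicity in this test and higher numbers for lower toxicity in this test. Compound 2 stands beside compound 1: the step of a 2.0-fold lower number from compound 1 to compound 2 (0.30 log units; within the scatter) lies within the scatter, so the two cannot be told apart on this read-out. Compound 3, `CCOc1ccsc1CN[C@@H]1C[C@H]2C[C@@H]([C@H]1C)C2(C)C`, differs from compound 2 in one place: ethoxy in place of thiophen-3-yl on an aromatic carbon. Within the data shown here, no measured step involves an ethoxy group, so nothing bears directly on this change; the only measured step is small. Compound 3 is therefore expected to stay near the two measured numbers, with a 2.0-fold higher number from compound 2 to compound 3 (0.30 log units; within the scatter) expected to be within the scatter. The estimate for compound 3 is 25000 nM, with a range from 6000 nM to 100000 nM.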

Compound 3, minimum cytotoxic concentration: 50000 nM
The estimate for compound 3 lay 2.0-fold (0.30 log units) below the measured number; low and high end bracket the measured number.
By their numbers in this assay, from the lowest: compounds 2, 1 and 3 (each within the scatter of the next, the first and the last beyond it).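

In this assay this position gives its first step beyond the scatter: ethoxy in place of thiophen-3-yl gives a 4.0-fold higher number from compound 2 to compound 3 (0.60 log units; beyond the scatter) as a modest change. Ethoxy in place of cyclopropyl gives a 2.0-fold higher number from compound 1 to compound 3 (0.30 log units; within the scatter) and stays within the scatter, so these two groups cannot be told apart on this read-out. No measured evidence accounts for the difference between ethoxy and thiophen-3-yl.

As far as these compounds go, what a longer chain such as butoxy, or an amine, would do at this place stays open. The compounds shown also leave open whether ethoxy would give a similar step on a different core.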